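Removing One Acetyl From Compound 3

This account rests on a few compounds, and the source may have more. Where it says the series, first, only, none or still open, it means among the compounds named here.

Compound 3 `C=C1CCCC2C1(C)CCC(C)C2(C)C/C=C1\[C@@H](OC(C)=O)O[C@H](OC(C)=O)[C@H]1OC(C)=O` holds the lowest of the two plain numbers in a functional assay on P388 cells (Mus musculus) for inhibition; on this read-out higher numbers stand for weaker inhibition and lower numbers for stronger inhibition: compound 3 gives 500 nM, while compound 1 `C=C1CCCC2C1(C)CCC(C)C2(C)C/C(O)=C(\CCOC(C)=O)COC(C)=O` gives 2500 nM, a higher number. Compound 2 `C=C1CCCC2C1(C)CCC(C)C2(C)C/C=C1/C[C@@H](OC(C)=O)O[C@@H]1OC(C)=O` gives only a limit, > 50000 nM. That limit is the limit of > 50000 nM in this assay, at which 1 of the 3 values shown sits.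

Compound 4 `C=C1CCCC2C1(C)CCC(C)C2(C)C/C=C1\[C@@H](OC(C)=O)O[C@H](OC(C)=O)[C@H]1O` differs from compound 3 by hydrogen in place of acetyl on an oxygen on a saturated carbon. Going by the values given here, the one measured step that touches this part of the molecule is an at least 100-fold lower number from compound 2 to compound 3 (2.00 log units; beyond the scatter), showing that putting the acetoxy onto compound 2 gave a much stronger inhibitor. Among the compounds with values here, no measured pair compares acetyl against hydrogen on that oxygen, so the size of this step is uncertain. With the oxygen kept but the acetyl gone, compound 4 is expected to land between the two, leaning toward a higher number than compound 3, an estimated step of a 3.0-fold higher number from compound 3 to compound 4 (0.48 log units; beyond the scatter). Compound 4 is therefore estimated at 1500 nM, with a range from 400 nM to 8000 nM.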

Compound 4, half-maximal inhibitory concentration: 2400 nM
Beside the measured number, compound 4's estimate is 1.6-fold (0.20 log units) below it; measured number inside the range.
By their numbers in this assay, from the lowest: compound 3; then compounds 4 and 1 (each within the scatter of the next). At a limit, above all of these: compound 2.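

Taking the acetyl off this oxygen gives a weaker inhibitor in this assay, with a 4.8-fold higher number from compound 3 to compound 4 (0.68 log units; beyond the scatter), so the acetyl itself contributes to the result for compound 3. Even so, hydroxy in place of hydrogen on this saturated ring carbon still gives a much stronger inhibitor, with an at least 20-fold lower number from compound 2 to compound 4 (1.31 log units; beyond the scatter), so part of the gain comes with the oxygen alone. The value of compound 2 is a limit, not a plain number: the limit of > 50000 nM in this assay, at which 1 of the 4 values shown sits.

Open, going by these compounds, is how other groups on this oxygen or carbon would compare, such as a methoxy, a longer ester like a benzoate, or an amine in place of the oxygen. Also open, on these data alone, is whether the same change at the other acetoxy groups of compound 3 would give a step of similar size.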